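Methyl on the ring nitrogen of compound 3: no guide

The compounds below may be only part of what the source reports. "The series", "measured", "known", "first", "only" and "open" are said of these compounds alone.

Compound 1 `Clc1ccc(-c2noc(-c3cc4ccccc4[nH]3)n2)cc1` gives 19200 nM in a functional assay on MIA PaCa-2 cells (Homo sapiens) for antiproliferative activity, read by WST assay, with a stated time of 72 h; on this read-out lower numbers stand for stronger inhibition and higher numbers for weaker inhibition. Compound 2 `O=[N+]([O-])c1ccc2[nH]c(-c3nc(-c4ccc(Cl)cc4)no3)cc2c1` gives 17600 nM in this assay, and the step of a 1.1-fold lower number from compound 1 to compound 2 (0.04 log units; within the scatter) stays within the scatter. Compound 3 `Clc1ccc(-c2noc(-c3cc4cc(Cl)ccc4[nH]3)n2)cc1` returns only a limit, > 50000 nM, in this assay. That puts compound 3 at the limit of > 50000 nM in this assay, at which 1 of the 3 values shown sits, so its standing on the numbers is known only as a floor. Both steps leading to it, an at least 2.6-fold higher number from compound 1 to compound 3 (0.41 log units; beyond the scatter) and an at least 2.8-fold higher number from compound 2 to compound 3 (0.45 log units; beyond the scatter), lie beyond the scatter, and on those steps compound 3 is the weakest of the three.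

Compound 4 `Cn1c(-c2nc(-c3ccc(Cl)cc3)no2)cc2cc(Cl)ccc21` differs from compound 3 by methyl in place of hydrogen on an aromatic nitrogen. For the measured compounds named here, none of the measured steps touches this ring nitrogen; each concerns a group on an aromatic carbon. Going by the values given here, no measured step therefore bears on this change, and no step beyond the scatter is expected in this assay. Compound 4 is expected to sit near the same limit, the step that the limit leaves unreadable from compound 3 to compound 4 being the estimate. The estimated value for compound 4 is 70000 nM, within a range from 25000 nM to 200000 nM.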

Compound 4, half-maximal inhibitory concentration: > 50000 nM
Compound 4: only a limit was reported (the forecaster's own chance of this, stated with the estimate: 70%); the middle value lies beyond the limit too.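

Compound 3 and compound 4 each return only a limit in this assay, so the step between them cannot be read: the limit of > 50000 nM in this assay, at which 2 of the 4 values shown sit.

The compounds shown leave open whether methyl in place of hydrogen on the aromatic nitrogen changes the read-out, and how far either compound lies past that limit.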